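Substituent on the ring nitrogen: expectation for compound 4

A few compounds are considered here, and "the series" means these few. Any claim that something is new, unique, unknown or untested is made for them only; others in the source may bear on it.

Measured compounds in an assay on CHO cells for displacement of a labelled ligand from adenosine receptor A1 (Homo sapiens), read by scintillation counting, with a stated time of 60 min, tested at 10 uM; on this read-out higher numbers stand for more inhibition at the one concentration tested (going by the name of the read-out) and lower numbers for less inhibition:
compound 1, `CCCCC#Cc1nc(NCc2cccc(I)c2)c2ncn([C@H]3[C@H](O)[C@H](O)[C@@H]4C[C@@H]43)c2n1`, gives 48%
compound 2, `CCCCC#Cc1nc(NC)c2ncn([C@H]3[C@H](O)[C@H](O)[C@@H]4C[C@@H]43)c2n1`, gives 14%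
compound 3, `CCCCC#Cc1nc(N)c2ncn([C@H]3[C@H](O)[C@H](O)[C@@H]4C[C@@H]43)c2n1`, gives 29%

Compound 3 stands second highest of the three numbers in this assay. Its nearest neighbour is compound 2, a number 15 percentage points higher from compound 2 to compound 3 (beyond the scatter); its furthest is compound 1, a number 19 percentage points lower from compound 1 to compound 3 (beyond the scatter). The step of a number 34 percentage points lower from compound 1 to compound 2 (beyond the scatter) shows the benzyl group carrying most of the difference within this set.

Compound 4, `CCCCC#Cc1nc(NCc2cccc(F)c2)c2ncn([C@H]3[C@H](O)[C@H](O)[C@@H]4C[C@@H]43)c2n1`, is the unmeasured member. Its difference from compound 3 is 3-fluorobenzyl in place of hydrogen on a nitrogen on an aromatic ring. Within the data shown here, the step that bears most directly on this change is the reverse of a number 19 percentage points lower from compound 1 to compound 3 (beyond the scatter), where a 3-iodobenzyl on the same nitrogen went with the higher number; the fluorine analogue has no direct precedent here, so the size is uncertain. A rise beyond the scatter is expected for compound 4, a number 16 percentage points higher from compound 3 to compound 4 (beyond the scatter), in this assay. The estimate for compound 4 in this assay is 45%, expected to fall between 28% and 62%.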

Compound 4, a percentage reported as inhibition, at one concentration (the size of the read-out at that concentration, not a potency): 21%
Estimate against measurement, compound 4: 24 percentage points above; measured number below the stated range.
By their numbers in this assay, from the lowest: compounds 2, 4 and 3 (each within the scatter of the next, the first and the last beyond it); then compound 1.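

In this assay, a benzyl group on the ring nitrogen does not by itself go with more inhibition: 3-fluorobenzyl in place of hydrogen gives a number 8 percentage points lower from compound 3 to compound 4 (within the scatter) and, set against the methyl group, gives a number 7 percentage points higher from compound 2 to compound 4 (within the scatter) on the same read-out. The substituent on the benzyl ring is what separates the two benzyl compounds, with fluoro in place of iodo giving a number 27 percentage points lower from compound 1 to compound 4 (beyond the scatter) here. The higher number of compound 1 therefore goes with 3-iodobenzyl specifically and not with benzyl substitution in general, and nothing available explains the gap between fluoro and iodo.

Unsubstituted benzyl, 3-chlorobenzyl and 3-bromobenzyl on this nitrogen remain open, so it cannot be said whether iodo stands alone or ends a trend. On these data alone, a longer chain such as 2-phenylethyl is also open, as is how these single-concentration numbers relate to potency.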